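The source may hold more compounds than are shown below. What is called first, only, known or untested is meant among the compounds shown, and "the series" means these compounds.

Within the data shown here, compound 1 `FC(F)(F)c1ccc(NC2=NCCC3(CCCCC3)S2)cc1` has the highest number of the three compounds measured so far: in a functional assay on a subcellular fraction from brain (Rattus norvegicus) for inhibition, read by scintillation counting, with a stated time of 5 min (a higher number here means a weaker inhibitor, a lower number a stronger inhibitor), compound 1 gives 77600 nM. The nearest to it is compound 3 `Cc1cccc(C(C)C)c1NC1=NCCC2(CCCCC2)S1`, which in this assay gives 20900 nM; the furthest is compound 2 `Cc1cc(C)c(NC2=NCCC3(CCCCC3)S2)c(C)c1`, which in this assay gives 9300 nM. Both gaps lie beyond the scatter of repeated measurement, so compound 1 is the weakest inhibitor of the set.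

Compound 4 `CCc1ccc(NC2=NCCC3(CCCCC3)S2)cc1` shares the core of compound 1 and differs from it in one place: ethyl in place of trifluoromethyl on an aromatic carbon. Among the measured compounds shown here, no measured pair in this set shows the same change, so the size of the step cannot be read off directly. The two compounds that carry no trifluoromethyl group, compound 2 at 9300 nM and compound 3 at 20900 nM, both stand well below compound 1 in this assay. On that basis a moderate move toward a lower number is expected for compound 4, a step of about a 2.6-fold lower number from compound 1 to compound 4 (0.41 log units; beyond the scatter). Compound 4 is estimated at 30000 nM in this assay, with a likely range from 10000 nM to 90000 nM.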

Compound 4, half-maximal inhibitory concentration: 11700 nM
The estimate for compound 4 lay 2.6-fold (0.41 log units) above the measured number; the measured number falls inside the stated range.
By their numbers in this assay, from the lowest: compounds 2, 4 and 3 (each within the scatter of the next, the first and the last beyond it); then compound 1.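

Replacing trifluoromethyl with ethyl on this aromatic carbon, para to a large group, gives a 6.6-fold lower number from compound 1 to compound 4 (0.82 log units; beyond the scatter) in this assay. Among these compounds, the earlier compounds differed from one another in more than one place, so this pair is the first to show that a change at this position alone, with the shared core unchanged, can move the number beyond the scatter. The data offer no measured property of either group that would account for the step.

From the compounds shown here alone, whether a longer chain such as propyl, an amine or a methoxy group at this position would give a lower or a higher number remains open. Going by these compounds, it is also open whether the same exchange would give a step of similar size on the aromatic rings of compound 2 and compound 3.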